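Chloro to Methoxy on Two Related Cores

The source may report more compounds than this note shows. Statements on the series, on what has been measured and on what is new or still open speak of the compounds shown alone.

Compound 1 `Clc1ccc(C2CC(c3ccccc3)=NN2c2ccc(-c3ccccc3)nn2)cc1` and compound 3 `Clc1ccc(C2=NN(c3ccc(-c4ccccc4)nn3)C(c3ccccc3)C2)cc1` are built from the same atoms joined differently; the difference between the two cores is not broken down here. In a functional assay on Caco-2 cells (Homo sapiens) for antiproliferative activity, read by MTT assay, with a stated time of 24 h (on this read-out higher numbers stand for weaker inhibition and lower numbers for stronger inhibition), compound 1 gives 100000 nM. In this assay compound 3 gives 100000 nM, level with compound 1 within the usual scatter. Compound 2 `COc1ccc(C2CC(c3ccccc3)=NN2c2ccc(-c3ccccc3)nn2)cc1` differs from compound 1 by a single change, (methoxy in place of chloro on an aromatic carbon). In this assay compound 2 reaches only a limit of the assay, > 100000 nM. The step of a number no lower from compound 1 to compound 2 (the limit leaves the size open) therefore has no readable size, and one of the three values sits at the limit of > 100000 nM in this assay, at which 1 of the 3 values shown sits.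

Compound 4 `COc1ccc(C2=NN(c3ccc(-c4ccccc4)nn3)C(c3ccccc3)C2)cc1` carries the same change, made on the core of compound 3 at the same place, (methoxy in place of chloro on an aromatic carbon). Because the measured step of a number no lower from compound 1 to compound 2 (the limit leaves the size open) gave a number no lower, the step of no change at the digits printed from compound 3 to compound 4 (within the scatter) is expected to be no lower as well. Compound 4 is expected to give about 100000 nM, quite possibly again only a limit, somewhere between 50000 nM and 200000 nM.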

Compound 4, half-maximal inhibitory concentration: > 100000 nM
Compound 4: no number, only a limit; the forecaster's own chance of this, stated with the estimate: 60%; the middle value sits exactly at the limit.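

In this assay compound 4 gives > 100000 nM, which is a limit of the assay and not a number. Putting methoxy in place of chloro therefore gives a number no lower from compound 3 to compound 4 (the limit leaves the size open), the same direction as on the other core, which is all that carries over from one core to the other; neither step can be read as a size, so it cannot be said whether the change does the same thing on both: the same change on two cores in this assay, a number no lower (the limit leaves the size open) from compound 1 to compound 2 and a number no lower (the limit leaves the size open) from compound 3 to compound 4; the limit leaves it open whether they differ With so many results at the limit, these compounds show little about how the two cores compare in their response to this change: the limit of > 100000 nM in this assay, at which 2 of the 4 values shown sit.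

The compounds shown leave open whether any other group at this place, such as an amine or a carboxylic acid, would give a value clearly lower than those of compound 1 and compound 3. They also leave open whether methoxy and chloro differ in this assay at all, since a real number for methoxy is missing on both cores.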